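The source may hold more compounds than are shown below. What is called first, only, known or untested is meant among the compounds shown, and "the series" means these compounds.

In a functional assay on MDA-MB-231 cells (Homo sapiens) for inhibition, read by MTT assay, with a stated time of 72 h (a higher number here means a weaker inhibitor, a lower number a stronger inhibitor), compound 1 (`O=[N+]([O-])c1ccc(Nc2nnc(-c3c[nH]c4ccccc34)o2)cc1`) gives 3540 nM. Compound 2 (`Fc1ccc(Nc2nnc(-c3c[nH]c4ccccc34)o2)cc1`) gives > 100000 nM, which is a limit of the assay and not a number. As far as these compounds go, compound 2 therefore stands at the limit of > 100000 nM in this assay, at which 1 of the 2 values shown sits, and how weak it really is remains unknown.

Compound 3 (`COc1ccc(Nc2nnc(-c3c[nH]c4ccccc34)o2)cc1`) has methoxy in place of fluoro on an aromatic carbon, para to a large group: methoxy in place of fluoro on an aromatic carbon.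

Among the measured compounds shown here, only one measured step involves this same place on the molecule. That step is an at least 28-fold higher number from compound 1 to compound 2 (1.45 log units; beyond the scatter), a large change that lies beyond the scatter. For the measured compounds named here, it shows that swapping the group here can shift the result strongly in this assay, but it replaces nitro, and no measured compound carries methoxy. It therefore gives the likely scale of a change rather than a firm guide to its size. A modest move towards a lower number, meaning a stronger inhibitor, is the most reasonable expectation, and a reading that stays at the limit would be no surprise. The expected change is an at least 2.5-fold lower number from compound 2 to compound 3 (0.39 log units; beyond the scatter). The estimated value for compound 3 is 40000 nM, with an expected range from 8000 nM to 100000 nM.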

Compound 3, half-maximal inhibitory concentration: 10100 nM
For compound 3 the middle estimate is 4.0-fold (0.60 log units) above the measured one, and the stated range covers the measured number.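

In this assay, putting methoxy in place of fluoro gives an at least 9.9-fold lower number from compound 2 to compound 3 (0.99 log units; beyond the scatter), so a group other than nitro can also bring a measurable reading at this position on the aromatic ring. Moving from nitro to methoxy gives a 2.9-fold higher number from compound 1 to compound 3 (0.46 log units; beyond the scatter), which is the first comparison at this place between two real numbers, as the earlier step ended at a limit; it shows that methoxy gives a weaker inhibitor than nitro here, though the gap is modest. Compound 2 remains a limit of the assay and not a number, so the true size of the gain from fluoro to methoxy stays unknown: the limit of > 100000 nM in this assay, at which 1 of the 3 values shown sits.

Three groups at one position cannot show what sets their order, and the compounds shown do not tell how an amine, a hydroxyl group or a chlorine atom would read at this same place. As far as these compounds go, it also remains open whether a longer chain such as ethoxy would give a stronger or a weaker inhibitor than methoxy does.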